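Chain substituents on the amide of the nitro chromene core

The source may hold more compounds than are shown below. What is called first, only, known or untested is meant among the compounds shown, and "the series" means these compounds.

Measured in a functional assay on the whole organism (muscle tissue) with Rattus norvegicus as the target; a higher number here means a larger maximal response, a lower number a smaller maximal response:
compound 1, `CNC(=O)C1=CC(C)(C)Oc2ccc([N+](=O)[O-])cc21`: 61%
compound 2, `CCNC(=O)C1=CC(C)(C)Oc2ccc([N+](=O)[O-])cc21`: 80.5%
compound 3, `CC1(C)C=C(C(=O)NCCO)c2cc([N+](=O)[O-])ccc2O1`: 71.8%

Compound 3 stands second highest of the three numbers; its gap to compound 2 lies within the scatter (a number 8.7 percentage points lower from compound 2 to compound 3 (within the scatter)), while its gap to compound 1 lies beyond it (a number 10.8 percentage points higher from compound 1 to compound 3 (beyond the scatter)). Compound 4, `CC1(C)C=C(C(=O)NCCC#N)c2cc([N+](=O)[O-])ccc2O1`, differs from compound 3 as follows: cyano in place of hydroxy on a saturated chain carbon, two bonds along the chain from an amide-type nitrogen. Within the data shown here, the only measured step at this place, a number 8.7 percentage points lower from compound 2 to compound 3 (within the scatter), is small, and the larger step of a number 19.5 percentage points higher from compound 1 to compound 2 (beyond the scatter) concerns the carbon bound to the nitrogen, not this one. No step beyond the scatter is therefore expected for a number 0.2 percentage points higher from compound 3 to compound 4 (within the scatter). Compound 4 is estimated at 72%, within a range of 58% to 86%.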

Compound 4, intrinsic activity: the largest response reached, in percent of the reference agonist's: 73.1%
Compound 4: the middle estimate sits 1.1 percentage points below what was measured, within the range that was stated.
By their numbers in this assay, from the lowest: compound 1; then compounds 3, 4 and 2 (each within the scatter of the next).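

In this assay, the end of the chain can carry cyano in place of hydroxy, losing the hydrogen-bond donor, with no step beyond the scatter: a number 1.3 percentage points higher from compound 3 to compound 4 (within the scatter). Compound 4 also stays within the scatter of the unsubstituted chain, a number 7.4 percentage points lower from compound 2 to compound 4 (within the scatter), while cyanomethyl in place of hydrogen on the carbon bound to the amide-type nitrogen keeps a step beyond the scatter, a number 12.1 percentage points higher from compound 1 to compound 4 (beyond the scatter). No measurement at hand explains these results. Going by these compounds, whether an amine, a carboxylic acid or a longer chain at this place would stay within the same scatter remains open.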